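One Side Group Exchanged, One Number Awaited

The source may report more compounds than this note shows. Statements on the series, on what has been measured and on what is new or still open speak of the compounds shown alone.

In a physicochemical assay for lipophilicity, measured as octanol-water partition, at pH 7.4 (on this read-out higher numbers stand for higher lipophilicity and lower numbers for lower lipophilicity), compound 1 `Cc1ccc(Cn2c(=O)[nH]c3c(N)nc(-c4ncco4)cc32)cn1` gives 1.6 and compound 2 `Cc1nc(Cn2c(=O)[nH]c3c(N)nc(C(F)(F)F)cc32)cs1` gives 2.3 as the higher of the two numbers, with a gap beyond the scatter. Compound 3 `Nc1ccc(Cn2c(=O)[nH]c3c(N)nc(C(F)(F)F)cc32)cn1` has not yet been measured. It carries 6-aminopyridin-3-yl in place of 2-methyl-1,3-thiazol-4-yl on a saturated chain carbon bound to an aromatic nitrogen. Among the measured compounds shown here, no measured pair shows this change alone, so the step remains a judgement. A downward step beyond the scatter is expected (a number 0.80 log units lower from compound 2 to compound 3 (beyond the scatter)). In this assay compound 3 is estimated at 1.5 (expected range 1.1 to 1.9).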

Compound 3, distribution coefficient: 1.5
The estimate for compound 3 equals the measured number at the digits printed; the measured number falls inside the stated range.
By their numbers in this assay, from the lowest: compounds 3 and 1 (each within the scatter of the next); then compound 2.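

In this assay, placing 6-aminopyridin-3-yl in place of 2-methyl-1,3-thiazol-4-yl on a saturated chain carbon bound to an aromatic nitrogen gives a number 0.80 log units lower from compound 2 to compound 3 (beyond the scatter). Among the compounds shown here, compounds 1 and 2 differ in more than one place, so this is the first reading of a change at this position alone. No measurement available here explains the step. Going by these compounds, what a 6-methoxypyridin-3-yl group would give at this place remains open. So does whether the same step would hold with a group other than trifluoromethyl on the shared core.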